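A few compounds are considered here, and "the series" means these few. Any claim that something is new, unique, unknown or untested is made for them only; others in the source may bear on it.

Measured so far in a functional assay on HepG2 cells (Homo sapiens) for cytotoxicity, read by XTT assay, with a stated time of 6 days; on this read-out higher numbers stand for weaker inhibition and lower numbers for stronger inhibition:
Compound 1 `c1coc(-c2ncnc3[nH]cc(Sc4cccs4)c23)c1`: > 25000 nM (a limit)
Compound 2 `Cc1ncnc2[nH]cc(Sc3cccs3)c12`: > 25000 nM (a limit)

In this assay compound 2 is known only through the limit > 25000 nM, not through a number. The whole record so far is the limit of > 25000 nM in this assay, at which 2 of the 2 values shown sit. Compound 3 `COc1ncnc2[nH]cc(Sc3cccs3)c12` has methoxy in place of methyl on an aromatic carbon, next to the ring nitrogen: methoxy in place of methyl on an aromatic carbon. Going by the values given here, one measured step bears on the series, a step that the two limits leave unreadable from compound 1 to compound 2, and it offers no size to carry over. Among the compounds with values here, no measured step covers this exchange. No step beyond the scatter is therefore expected in this assay, and a report of only a limit is the likely outcome. The expected step is a number no higher from compound 2 to compound 3 (the limit leaves the size open). For compound 3 the estimated value is 25000 nM, with an expected range from 10000 nM to 50000 nM.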

Compound 3, half-maximal inhibitory concentration: > 25000 nM
Compound 3 gave a limit, no number; the forecaster's own chance of this, stated with the estimate: 85%; the middle value sits exactly at the limit.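

In this assay compound 3 gave > 25000 nM as a limit, not a number. Going by these compounds alone, no step among compound 1, compound 2 and compound 3 can be read: the limit of > 25000 nM in this assay, at which 3 of the 3 values shown sit. The compounds shown leave open how far any of them lies from that limit.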